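Moving a hydroxyl from the meta to the para position

This account rests on a few compounds, and the source may have more. Where it says the series, first, only, none or still open, it means among the compounds named here.

Of the compounds shown here, three have been measured in a functional assay on T47D cells (Homo sapiens) for inhibition; on this read-out higher numbers stand for weaker inhibition and lower numbers for stronger inhibition. Compound 1, `Oc1ccc(-c2cc(-c3cccc(F)c3)cc(-c3cccc(O)c3)n2)cc1`, gives 3510 nM in this assay. Compound 2, `Oc1ccc(-c2cc(-c3cccc(F)c3)cc(-c3ccc(O)cc3)n2)cc1`, reaches only a limit of the assay and not a number, > 50000 nM in this assay. Compound 3, `Oc1cccc(-c2cc(-c3ccccc3C(F)(F)F)cc(-c3ccccc3O)n2)c1`, gives 5680 nM in this assay. The change 4-hydroxyphenyl in place of 3-hydroxyphenyl on an aromatic carbon gives an at least 14-fold higher number from compound 1 to compound 2 (1.15 log units; beyond the scatter), and the value of compound 2 sits at the limit of > 50000 nM in this assay, at which 1 of the 3 values shown sits.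

Compound 4, `Oc1ccc(-c2cc(-c3ccccc3C(F)(F)F)cc(-c3ccccc3O)n2)cc1`, is not yet measured. It differs from compound 3 by 4-hydroxyphenyl in place of 3-hydroxyphenyl on an aromatic carbon. The difference between the core of compound 3 and the core of compound 1 is not broken down here. Among the compounds with values here, the change is the same kind of change as the one from compound 1 to compound 2, but the surroundings differ: in compound 1 the place is meta to a 3-fluorophenyl group and meta to a 4-hydroxyphenyl group, whereas in compound 3 it is meta to a 2-(trifluoromethyl)phenyl group and meta to a 2-hydroxyphenyl group. Because an at least 14-fold higher number from compound 1 to compound 2 (1.15 log units; beyond the scatter) was large, a similar weakening is expected, an 8.8-fold higher number from compound 3 to compound 4 (0.94 log units; beyond the scatter). Compound 4 is therefore estimated at 50000 nM in this assay, with a fair chance that only a limit is reported.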

Compound 4, half-maximal inhibitory concentration: 7180 nM
For compound 4 the middle estimate is 7.0-fold (0.84 log units) above the measured one; the whole stated range lies above it.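

In this assay, the change from 3-hydroxyphenyl to 4-hydroxyphenyl gives a 1.3-fold higher number from compound 3 to compound 4 (0.10 log units; within the scatter), so the large step seen on the core of compound 1 does not carry over in size to this core: the same change on two cores in this assay, an at least 14-fold higher number (1.15 log units; beyond the scatter) from compound 1 to compound 2 and a 1.3-fold higher number (0.10 log units; within the scatter) from compound 3 to compound 4, at least 11-fold (1.05 log units) apart, beyond the scatter of two such steps. The value of compound 2, > 50000 nM, is a limit of the assay and not a number. Within the data shown here, these results show that the effect of this change depends on the surrounding core, but with only two cores they give no general rule and do not show which difference between the cores matters.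

It remains open whether the 2-(trifluoromethyl)phenyl group, the 2-hydroxyphenyl group or both set the core of compound 3 apart from the core of compound 1, as the compounds shown offer no pair that separates these groups. Also open, as far as these compounds go, is how a phenyl ring carrying an amine or a carboxylic acid in place of the hydroxyl would read out at this place on either core.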